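Swapping an anilino for a methylated pyrrolidinone ring

The compounds below may be only part of what the source reports. "The series", "measured", "known", "first", "only" and "open" are said of these compounds alone.

Of the compounds shown here, three sharing one core have been measured in a physicochemical assay for lipophilicity, using the shake flask method, in phosphate buffer, measured as octanol-water partition, with a stated time of 30 min, at pH 7.4; a lower number here means a more polar compound, a higher number a more lipophilic compound. Compound 1, `O=C1CCCN1c1cnc(NCc2c(F)ccc3c2CCO3)n2cnnc12`, gives 1.3. Compound 2, `CN(c1cccnc1)c1cnc(NCc2c(F)ccc3c2CCO3)n2cnnc12`, gives 2.6. Compound 3, `Fc1ccc2c(c1CNc1ncc(Nc3ccccc3)c3nncn13)CCO2`, gives 3.3, the highest of the three: the step of a number 0.70 log units higher from compound 2 to compound 3 (beyond the scatter) is modest, and the step of a number 2.00 log units higher from compound 1 to compound 3 (beyond the scatter) is large.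

The next compound, compound 4, is `C[C@@H]1CC(=O)N(c2cnc(NCc3c(F)ccc4c3CCO4)n3cnnc23)C1`. Its change from compound 3 is 4-methyl-2-oxopyrrolidin-1-yl in place of anilino on an aromatic carbon. The step that bears on this most directly is the one in the opposite direction, a number 2.00 log units higher from compound 1 to compound 3 (beyond the scatter), where anilino replaced a plain 2-oxopyrrolidin-1-yl. Undoing that change should bring the number back down by roughly the same large amount. For the measured compounds named here, compound 4 differs from compound 1 only in the methyl on the 4-methyl-2-oxopyrrolidin-1-yl ring, and no measured pair covers that methyl, so the estimate is placed a little above the value of compound 1 rather than exactly on it. The expected step is therefore large and downward, a number 1.60 log units lower from compound 3 to compound 4 (beyond the scatter). Compound 4 is estimated in this assay at 1.7, with a range from 1.3 to 2.2.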

Compound 4, distribution coefficient: 1.8
Beside the measured number, compound 4's estimate is 0.10 log units below it; the range from low to high includes it.
By their numbers in this assay, from the lowest: compound 1; then compound 4; then compound 2; then compound 3.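

In this assay, one methyl on a saturated ring carbon of the group at this position gives a number 0.50 log units higher from compound 1 to compound 4 (beyond the scatter), so even this small addition to the 2-oxopyrrolidin-1-yl ring produces a shift larger than the usual scatter. The methylated ring still stands clearly apart from both amino groups, with a number 1.50 log units lower from compound 3 to compound 4 (beyond the scatter) and a number 0.80 log units lower from compound 2 to compound 4 (beyond the scatter); anilino and 4-methyl-2-oxopyrrolidin-1-yl have the same heavy-atom count, so that count alone does not separate them at this position. Nothing available here explains why these shifts occur.

The compounds shown leave open whether the opposite arrangement at the new stereocentre would give the same number as compound 4. They also leave open whether an ethyl group or a hydroxyl group on that same ring carbon would push the number further up or bring it back towards that of compound 1.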